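The source may hold more compounds than are shown below. What is called first, only, known or untested is meant among the compounds shown, and "the series" means these compounds.

Going by the values given here, the three compounds measured so far share a common core and all give low numbers in a functional assay on L5178Y cells (Mus musculus) for antiproliferative activity; a lower number here means a stronger inhibitor, a higher number a weaker inhibitor. Compound 1 `Nc1nc(=O)n(C2OC(CO)C(I)C2O)cc1F` gives 0.08 ug/mL in this assay. Compound 2 `Cc1ccc(S(=O)(=O)O[C@@H]2[C@@H](O)[C@H](n3ccc(N)nc3=O)O[C@@H]2CO)cc1` gives 0.08 ug/mL. Compound 3 `CS(=O)(=O)O[C@@H]1[C@@H](O)[C@H](n2cc(F)c(N)nc2=O)O[C@@H]1CO` gives 0.05 ug/mL, the lowest of the three numbers, though its gap to compound 1 and its gap to compound 2 both lie within the scatter, so no order among the three can be read from these figures.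

Compound 4 `Cc1ccc(S(=O)(=O)O[C@@H]2[C@@H](O)[C@H](n3cc(F)c(N)nc3=O)O[C@@H]2CO)cc1` has not yet been measured in this assay. It differs from compound 3 in one place: 4-methylphenyl in place of methyl on a sulfonyl sulfur. Among the compounds with values here, no measured pair isolates this change, so its effect cannot be read directly. Compound 2 carries the same 4-methylphenyl group on a sulfonyl sulfur, on a core that also differs from compound 4 in a second place, and in this assay compound 2 gives 0.08 ug/mL, a number within the scatter of that of compound 3. On that basis the step of a 1.4-fold higher number from compound 3 to compound 4 (0.15 log units; within the scatter) is expected to be small, with no clear direction and not beyond the scatter. Compound 4 is therefore estimated at 0.07 ug/mL, within a range from 0.03 ug/mL to 0.16 ug/mL.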

Compound 4, concentration for 50% inhibition: 0.06 ug/mL
The estimate for compound 4 lay 1.2-fold (0.07 log units) above the measured number, and the stated range covers the measured number.
By their numbers in this assay, from the lowest: compounds 3, 4, 1 and 2 (each within the scatter of the next).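

this assay now has its first pair that isolates the group on the sulfonyl sulfur: 4-methylphenyl in place of methyl gives a 1.2-fold higher number from compound 3 to compound 4 (0.08 log units; within the scatter), so bringing in the six-membered aromatic ring at this position produces no change that can be told from the scatter, and the shared core tolerates both groups here. Going by these compounds alone, the second pair isolates fluoro in place of hydrogen on an aromatic carbon, with a 1.3-fold lower number from compound 2 to compound 4 (0.12 log units; within the scatter), so with 4-methylphenyl on the sulfonyl sulfur this change likewise cannot be told from the scatter, a point that the earlier compounds, which differed from one another in more than one place, could not settle. No further measurement is available that would bear on either step.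

As far as these compounds go, it remains open what an amine or a longer chain such as butyl on the sulfonyl sulfur would give in this assay, and so whether any group at this position moves the number beyond the scatter. From the compounds shown here alone, it is also open whether chloro in place of fluoro on the aromatic carbon would do so.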